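The source may report more compounds than this note shows. Statements on the series, on what has been measured and on what is new or still open speak of the compounds shown alone.

Measured in a functional assay on HL-60 cells (Homo sapiens) for antiproliferative activity, read by MTT assay, with a stated time of 72 h; on this read-out lower numbers stand for stronger inhibition and higher numbers for weaker inhibition:
- compound 1 `COc1cc(C(=O)c2sc3ccccc3c2-c2ccccc2)cc(OC)c1OC`: 1700 nM
- compound 2 `COc1cc(C(=O)c2sc3ccccc3c2-c2ccc(F)cc2)cc(OC)c1OC`: 3200 nM
- compound 3 `COc1ccc(-c2c(C(=O)c3cc(OC)c(OC)c(OC)c3)sc3ccccc23)cc1C`: > 10000 nM, a limit and not a number

Compound 3 is reported in this assay only as a limit, > 10000 nM. It is the weakest of the three, and both of its steps lie beyond the scatter: an at least 5.8-fold higher number from compound 1 to compound 3 (0.76 log units; beyond the scatter), and an at least 3.1-fold higher number from compound 2 to compound 3 (0.49 log units; beyond the scatter). The other two compounds do not separate, with a 1.9-fold higher number from compound 1 to compound 2 (0.27 log units; within the scatter), which is within the scatter.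

Compound 4 `COc1cc(C(=O)c2sc3ccccc3c2Nc2ccccc2)cc(OC)c1OC` has not yet been measured. It keeps the shared core and changes one group: anilino in place of 4-methoxy-3-methylphenyl on an aromatic carbon. Anilino takes the place of 4-methoxy-3-methylphenyl on an aromatic carbon of a five-membered aromatic ring with 1 sulfur.

Among the compounds with values here, no measured step brings in anilino, so the evidence is indirect. The closest guide is that compound 3 lost ground when 4-methoxy-3-methylphenyl replaced phenyl, in an at least 5.8-fold higher number from compound 1 to compound 3 (0.76 log units; beyond the scatter). Losing that group should therefore move the number down, towards the level of compound 1 at 1700 nM, though not with much certainty.

The expected step is an at least 3.3-fold lower number from compound 3 to compound 4 (0.52 log units; beyond the scatter), towards stronger inhibition. The estimate for compound 4 is 3000 nM, with an expected range from 600 nM to 10000 nM.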

Compound 4, half-maximal inhibitory concentration: 5200 nM
Compound 4: middle estimate off by 1.7-fold (0.24 log units), on the low side; low and high end bracket the measured number.
By their numbers in this assay, from the lowest: compounds 1, 2 and 4 (each within the scatter of the next, the first and the last beyond it). At a limit, above all of these: compound 3.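

In this assay, the position two ring bonds from the ring sulfur accepts anilino with a modest cost against plain phenyl, a 3.1-fold higher number from compound 1 to compound 4 (0.49 log units; beyond the scatter), so this change of group does not leave the compound as weak as 4-methoxy-3-methylphenyl may have. Against 4-fluorophenyl, anilino cannot be told apart, a 1.6-fold higher number from compound 2 to compound 4 (0.21 log units; within the scatter), so a hydrogen-bond donor in the entering group, which the phenyl groups lack, gives no measurable gain over compound 2 and a loss against compound 1. Compound 3 is reported only as a limit, which leaves just a floor for its step, an at least 1.9-fold lower number from compound 3 to compound 4 (0.28 log units; that floor lies within the scatter), and that floor cannot show how far anilino improves on 4-methoxy-3-methylphenyl: the limit of > 10000 nM in this assay, at which 1 of the 4 values shown sits.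

The compounds shown leave open whether the loss from phenyl to anilino belongs to the nitrogen itself or to its hydrogen, a question that N-methylanilino, phenoxy or benzyl at the same place would address. They also leave open whether a substituent on the anilino ring, such as fluoro or methoxy, would shift the number in either direction.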